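From Cyclohexylmethyl to 2-Cyclohexylethyl in Compound 3

The compounds below may be only part of what the source reports. "The series", "measured", "known", "first", "only" and "open" are said of these compounds alone.

In a functional assay on SH-SY5Y cells (Homo sapiens) for cytotoxicity (on this read-out lower numbers stand for stronger inhibition and higher numbers for weaker inhibition), compound 1 (`CCCCCC(CCCCC)c1nc(-c2ccc(F)cc2)c[nH]1`) gives 770 nM and compound 2 (`CCCC(CCC)c1nc(-c2ccc(C(C)(C)C)cc2)c[nH]1`) gives 430 nM while compound 3 (`c1ccc(-c2ccc(-c3c[nH]c(CCC4CCCCC4)n3)cc2)cc1`) gives 760 nM as its reading. Compound 3 stands within the usual scatter of both others, so these numbers do not rank the three. Compound 4 (`c1ccc(-c2ccc(-c3c[nH]c(CCCC4CCCCC4)n3)cc2)cc1`) differs from compound 3 in one place: cyclohexylmethyl in place of cyclohexyl on a saturated chain carbon, two bonds along the chain from an aromatic carbon. Among the measured compounds shown here, with compound 3 at 760 nM as the reference and no measured pair showing such a change, no step beyond the scatter is expected in this assay in either direction. The estimated step of a 1.1-fold lower number from compound 3 to compound 4 (0.04 log units; within the scatter) stays within that scatter. Compound 4 is estimated at 700 nM with an expected range from 300 nM to 1600 nM on this read-out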

Compound 4, half-maximal inhibitory concentration: 1000 nM
For compound 4 the middle estimate is 1.4-fold (0.15 log units) below the measured one, and the stated range covers the measured number.
By their numbers in this assay, from the lowest: compounds 2, 3, 1 and 4 (each within the scatter of the next, the first and the last beyond it).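

In this assay, among the compounds shown here, cyclohexylmethyl in place of cyclohexyl on a saturated chain carbon, two bonds along the chain from an aromatic carbon, gives a 1.3-fold higher number from compound 3 to compound 4 (0.12 log units; within the scatter) as the first measured step at this position. In this single pair, the added chain length does not move the reading beyond the usual scatter. Nothing available bears on what lies behind this result.

Still open, going by these compounds, is whether a longer chain, a phenyl ring in place of the cyclohexyl ring, or an amine on the chain would give a step beyond the scatter.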